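The source may report more compounds than this note shows. Statements on the series, on what has been measured and on what is new or still open speak of the compounds shown alone.

Compound 3, with structure `Nc1scc(CN2CCN(c3cc(F)cc(F)c3)CC2)c1C(=O)c1ccc(Cl)cc1`, is one of three members of a shared series examined in a functional assay on CHO cells with adenosine receptor A1 (Homo sapiens) as the target, read by cAMP accumulation and immunoassay, with a stated time of 6 min, tested at 1 uM (on this read-out higher numbers stand for a weaker effect at the one concentration tested and lower numbers for a stronger effect), where compound 3 gives -66%. Among the three numbers it stands second highest. Compound 1, with structure `Nc1scc(CN2CCN(c3cc(Cl)cc(Cl)c3)CC2)c1C(=O)c1ccc(Cl)cc1`, is the nearest, giving -69% in this assay; the step of a number 3 percentage points higher from compound 1 to compound 3 (within the scatter) is within the scatter. Compound 2, with structure `Nc1scc(CN2CCN(c3cccnc3)CC2)c1C(=O)c1ccc(Cl)cc1`, is the furthest, giving -2.7% in this assay; the step of a number 63.3 percentage points lower from compound 2 to compound 3 (beyond the scatter) is beyond the scatter.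

Compound 4, with structure `Nc1scc(CN2CCN(c3cc(Cl)ccc3Cl)CC2)c1C(=O)c1ccc(Cl)cc1`, has not yet been measured in this assay. Its structure differs from compound 3 by 2,5-dichlorophenyl in place of 3,5-difluorophenyl on an amine nitrogen in a ring.

Among the measured compounds shown here, two steps bear on this change. The exchange of 3,5-difluorophenyl for 3,5-dichlorophenyl, a number 3 percentage points higher from compound 1 to compound 3 (within the scatter), stayed within the scatter, while the exchange of an aromatic ring of carbon only for pyridin-3-yl, a number 66.3 percentage points higher from compound 1 to compound 2 (beyond the scatter), was large. Compound 4 keeps an aromatic ring of carbon only with two halogens, so the step of a number 11 percentage points higher from compound 3 to compound 4 (beyond the scatter) is expected to stay small. Compound 4 is therefore estimated to give -55% in this assay, between -80% and -20%.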

Compound 4, a percentage reported as activity, at one concentration (the size of the read-out at that concentration, not a potency): -42%
Compound 4: the middle estimate sits 13 percentage points below what was measured; the range from low to high includes it.
By their numbers in this assay, from the lowest: compounds 1 and 3 (each within the scatter of the next); then compound 4; then compound 2.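

In this assay the placing of the halogens on this ring now shows an effect that the two 3,5-disubstituted compounds could not show, as 2,5-dichlorophenyl in place of 3,5-dichlorophenyl, with the same two chlorines, gives a number 27 percentage points higher from compound 1 to compound 4 (beyond the scatter) and the change from 3,5-difluorophenyl gives a number 24 percentage points higher from compound 3 to compound 4 (beyond the scatter) as well. The dihalophenyl group of compound 4 still stands well apart from pyridin-3-yl, with a number 39.3 percentage points lower from compound 2 to compound 4 (beyond the scatter) on the same amine nitrogen, so this change costs less than the exchange for pyridin-3-yl. Nothing available accounts for this shift.

As far as these compounds go, whether the shift follows the arrangement of the halogens in 2,5-dichlorophenyl itself or the chlorines in it remains open, and a difluorophenyl group with its fluorines placed as these chlorines are would separate the two. From the compounds shown here alone, how a single chlorine, a methoxy group or an unsubstituted phenyl ring would read here also stays unknown.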